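A few compounds are considered here, and "the series" means these few. Any claim that something is new, unique, unknown or untested is made for them only; others in the source may bear on it.

In a functional assay on HeLa cells (Homo sapiens) for cytotoxicity, read by WST assay, with a stated time of 48 h (a lower number here means a stronger inhibitor, a higher number a weaker inhibitor), three compounds built on a shared core have been measured. Compound 1 (`COc1cc(C(c2ccc(O)c(OC)c2)[C@@H](C)[C@@H](C)CF)ccc1O`) gives 42000 nM and compound 2 (`COc1cc(C(c2ccc(O)c(OC)c2)[C@@H](C)[C@H](C)CF)ccc1O`) gives 37000 nM. These two differ only in configuration as drawn, and the record shows a 1.1-fold lower number from compound 1 to compound 2 (0.06 log units; within the scatter). Compound 3 (`COc1cc(C(c2ccc(O)c(OC)c2)[C@H](CC(C)C)C(C)C)ccc1O`) gives 8200 nM, the lowest of the three numbers, with both gaps beyond the scatter.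

Compound 4 (`COC[C@@H](C)[C@H](C)C(c1ccc(O)c(OC)c1)c1ccc(O)c(OC)c1`) carries 2-(methoxymethyl)-1-methylpropyl in place of 1-isopropyl-3-methylbutyl on a saturated chain carbon bound to two aromatic carbons. Among the measured compounds shown here, the steps that bear on this change are a 5.1-fold lower number from compound 1 to compound 3 (0.71 log units; beyond the scatter) and a 4.5-fold lower number from compound 2 to compound 3 (0.65 log units; beyond the scatter), in both of which 1-isopropyl-3-methylbutyl replaced 2-(fluoromethyl)-1-methylpropyl. The incoming chain of compound 4 shares its 1-methylpropyl frame with compound 1 and compound 2, so a modest step of similar size in the opposite direction is expected in this assay. The estimated change is a 3.9-fold higher number from compound 3 to compound 4 (0.59 log units; beyond the scatter). For compound 4 the expected value is 32000 nM, with an estimated range of 14000 nM to 70000 nM.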

Compound 4, half-maximal inhibitory concentration: 58000 nM
The estimate for compound 4 lay 1.8-fold (0.26 log units) below the measured number; measured number inside the range.
By their numbers in this assay, from the lowest: compound 3; then compounds 2, 1 and 4 (each within the scatter of the next).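

In this assay, replacing 1-isopropyl-3-methylbutyl with 2-(methoxymethyl)-1-methylpropyl on a saturated chain carbon bound to two aromatic carbons gives a 7.1-fold higher number from compound 3 to compound 4 (0.85 log units; beyond the scatter) and shows that the gap to compound 3 also appears with an oxygen-bearing chain, not only with the fluorinated ones. Methoxy in place of fluoro makes no difference beyond the scatter, with a 1.6-fold higher number from compound 2 to compound 4 (0.20 log units; within the scatter) and a 1.4-fold higher number from compound 1 to compound 4 (0.14 log units; within the scatter) as the two readings of that swap. Compounds 1, 2 and 4 therefore cannot be told apart here, and only compound 3 stands apart from all of them.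

The compounds shown leave open whether a hydroxyl, an amine or a carboxylic acid at the end of the same 1-methylpropyl frame would also fall with compounds 1, 2 and 4. Nothing given here accounts for the gap between compound 3 and the other three.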